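Fluoro to trifluoromethyl on the aryl ring: cytotoxicity notes

The compounds below may be only part of what the source reports. "The series", "measured", "known", "first", "only" and "open" are said of these compounds alone.

Measured in an ADME assay on MT4 cells (Homo sapiens) for cytotoxicity, read by MTT assay, with a stated time of 4 days; a higher number here means that more compound is tolerated, a lower number that less compound is tolerated:
compound 1 `Nc1ccc2oc(-c3cccc(F)c3)cc(=O)c2c1` gives 269000 nM
compound 2 `Nc1ccc2oc(-c3cccc(C(F)(F)F)c3)cc(=O)c2c1` gives 138000 nM
compound 3 `Nc1ccc2oc(-c3ccc(F)cc3)c(O)c(=O)c2c1` gives 92600 nM

Compound 1 and compound 2 share a core and differ by trifluoromethyl in place of fluoro on an aromatic carbon; this step gave a 1.9-fold lower number from compound 1 to compound 2 (0.29 log units; within the scatter). Compound 3 carries a different core, and the difference between the two cores is not broken down here. Compound 4 `Nc1ccc2oc(-c3ccc(C(F)(F)F)cc3)c(O)c(=O)c2c1` is not yet measured in this assay; it differs from compound 3 by trifluoromethyl in place of fluoro on an aromatic carbon. This is the same kind of change as that from compound 1 to compound 2, but not the same: in the earlier pair the trifluoromethyl stands meta to a large group, in the new pair para to a large group. With one earlier example only, the expectation for compound 4 rests on the step of a 1.9-fold lower number from compound 1 to compound 2 (0.29 log units; within the scatter) and on compound 3 giving 92600 nM. The step from compound 3 to compound 4 is expected to be a 1.6-fold lower number from compound 3 to compound 4 (0.20 log units; within the scatter). Compound 4 is therefore estimated at 58000 nM, expected to fall between 30000 nM and 120000 nM.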

Compound 4, half-maximal cytotoxic concentration: 3900 nM
Compound 4: the middle estimate sits 15-fold (1.17 log units) above what was measured; measured number below the stated range.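

In this assay, trifluoromethyl in place of fluoro does not carry over between these two pairs as a step of fixed size: the same change on two cores in this assay, a 1.9-fold lower number (0.29 log units; within the scatter) from compound 1 to compound 2 and a 24-fold lower number (1.38 log units; beyond the scatter) from compound 3 to compound 4, 12-fold (1.09 log units) apart, beyond the scatter of two such steps. The new step, a 24-fold lower number from compound 3 to compound 4 (1.38 log units; beyond the scatter), is large, so the small step on the core of compound 1 gives no safe guide to this change on the core of compound 3. The two pairs differ in the core and also in where the change falls, with the new one para to a large group, so these compounds cannot show which of the two separates the steps, and two pairs establish no rule for the series.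

Open, as far as these compounds go, is whether the same change para to a large group on the core of compound 1 would give a large step or a small one, which would help separate the core from the place. Also open, from the compounds shown here alone, is whether a smaller group such as chloro or methyl at that place on the core of compound 3 would move the number as far as trifluoromethyl does.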